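Removing the alkyne arm from the fused core

The source may report more compounds than this note shows. Statements on the series, on what has been measured and on what is new or still open speak of the compounds shown alone.

Compound 1 `O=c1nc2oc(C3CC3)c(C#CC3CC3)c2cn1Cc1cn(Cc2ccccc2)nn1` stands at the low end of the three numbers measured in a functional assay on HepG2 cells (Homo sapiens) for antiproliferative activity, read by MTT assay, with a stated time of 72 h (a higher number here means a weaker inhibitor, a lower number a stronger inhibitor), where compound 1 gives 2670 nM. Compound 2 `CCCCCCC#Cc1c(CCCCCC)oc2nc(=O)n(Cc3cn(Cc4ccccc4)nn3)cc12` differs from compound 1 at two places at once; in this assay compound 2 gives 25800 nM, so the two values show compound 2 well above compound 1. For the measured compounds named here, compound 3 `O=c1nc2oc(C3CC3)c(C#CC3CC3)c2cn1Cc1cn(-c2ccccc2F)nn1` gives 39100 nM in this assay, and the only single-point step among the measured compounds, a 15-fold higher number from compound 1 to compound 3 (1.17 log units; beyond the scatter), shows how sensitive this series is to a change at the group on the aromatic nitrogen.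

Compound 4 `O=c1nc2oc(C3CC3)cc2cn1Cc1cn(Cc2ccccc2)nn1` differs from compound 1 in one place: hydrogen in place of 2-cyclopropylethynyl on an aromatic carbon. Going by the values given here, no measured step touches this position, since the one recorded step sits on the other end of the molecule and compound 2 changes two groups together. What remains is that a group of five heavy atoms, one of them a small ring and a triple bond, is deleted outright, and the values of compound 1 and compound 2 suggest that alterations to this part of the core are not neutral. A weakening of moderate size, a 3.0-fold higher number from compound 1 to compound 4 (0.48 log units; beyond the scatter), is therefore expected. Compound 4 is estimated at 8000 nM, within a range of 2500 nM to 30000 nM.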

Compound 4, half-maximal inhibitory concentration: 49100 nM
Estimate against measurement, compound 4: 6.1-fold (0.79 log units) below, and the stated range ends below it.
By their numbers in this assay, from the lowest: compound 1; then compounds 2, 3 and 4 (each within the scatter of the next).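

For the compounds shown here, the step of an 18-fold higher number from compound 1 to compound 4 (1.26 log units; beyond the scatter) is the first direct reading at this position, the aromatic carbon next to the ring atom that bears a cyclopropyl group, and it shows that in this assay the 2-cyclopropylethynyl group cannot be replaced by hydrogen without a large loss. Going by these compounds alone, until now the only single-point step lay at the group on the aromatic nitrogen, with a 15-fold higher number from compound 1 to compound 3 (1.17 log units; beyond the scatter) as its reading, so large steps are now seen at two separate places on compound 1. Why removing the arm costs so much stays unexplained, as nothing available bears on the cause.

Going by these compounds, what a plain ethynyl, a methyl or an amine would give on this carbon stays open, so it cannot be said whether the triple bond or the three-membered ring matters more. Compound 2 also differs from compound 1 in the group bearing the ring next to this position, so its steps to the other compounds cannot be read as the effect of any one change.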